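The source may hold more compounds than are shown below. What is called first, only, known or untested is meant among the compounds shown, and "the series" means these compounds.

In a functional assay on Huh-7 cells (Homo sapiens) for inhibition, read by MTT assay, with a stated time of 72 h (on this read-out lower numbers stand for stronger inhibition and higher numbers for weaker inhibition), compound 1 (`Nc1nc2cc(-c3nn(CCCCCCCCCC(=O)NO)c4ncnc(N)c34)ccc2o1`) gives 41200 nM and compound 2 (`Nc1nc2cc(-c3nn(CCCCCC(=O)NO)c4ncnc(N)c34)ccc2o1`) gives 9910 nM, the lower of the two numbers. Compound 3 (`Nc1nc2cc(-c3nn(CCCCCCCCC(=O)NO)c4ncnc(N)c34)ccc2o1`) is still unmeasured. It differs from compound 2 by 3-(hydroxycarbamoyl)propyl in place of hydroxycarbamoyl on a saturated chain carbon, five bonds along the chain from an aromatic nitrogen, with 3-(hydroxycarbamoyl)propyl in place of hydroxycarbamoyl on a saturated chain carbon, five bonds along the chain from an aromatic nitrogen. Among the measured compounds shown here, the only measured step bearing on this is a 4.2-fold lower number from compound 1 to compound 2 (0.62 log units; beyond the scatter), which shortened the same chain. Compound 3 has a chain between those of the other two, so most of that step should be reversed in this assay. The expected change is a 2.8-fold higher number from compound 2 to compound 3 (0.45 log units; beyond the scatter). For compound 3 the estimated value is 28000 nM, with an expected range of 11000 nM to 60000 nM.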

Compound 3, half-maximal inhibitory concentration: 1470 nM
For compound 3 the middle estimate is 19-fold (1.28 log units) above the measured one; the measured number lies below the stated range.
By their numbers in this assay, from the lowest: compound 3; then compound 2; then compound 1.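

In this assay the number does not follow chain length in one direction: 3-(hydroxycarbamoyl)propyl in place of hydroxycarbamoyl gives a 6.7-fold lower number from compound 2 to compound 3 (0.83 log units; beyond the scatter), and hydroxycarbamoyl in place of (hydroxycarbamoyl)methyl gives a 28-fold lower number from compound 1 to compound 3 (1.45 log units; beyond the scatter). Of the three compounds, the lowest number therefore belongs to compound 3, whose chain is longer than that of compound 2 and shorter than that of compound 1. Nothing available explains this turn in the numbers. The compounds shown leave open how the number changes at other chain lengths, and whether a carboxylic acid at the chain end could stand in for the hydroxycarbamoyl group.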